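From chloro to methyl: compound 3 and compound 4

The source may report more compounds than this note shows. Statements on the series, on what has been measured and on what is new or still open speak of the compounds shown alone.

Measured so far in a physicochemical assay for lipophilicity, read by LC-MS, in phosphate buffer, measured as octanol-water partition, with a stated time of 30 min, at pH 7.4, tested at 200 mM; a higher number here means a more lipophilic compound, a lower number a more polar compound:
Compound 1 `Cn1c(COc2cccc(C(=O)O)c2)nc2cnc(Oc3ccc(Cl)c(F)c3)cc21` gives 1.4
Compound 2 `Cn1c(COc2cccc(C(=O)O)c2)nc2cnc(Oc3ccc4c(c3)CCC4)cc21` gives 1.6
Compound 3 `Cn1c(COc2cccc(C(=O)O)c2)nc2ccc(Oc3cccc(Cl)n3)cc21` gives 1.2

Compound 3 lies within the scatter of compound 1, while compound 2 stands higher than compound 3, beyond the scatter. Compound 4 `Cc1cccc(Oc2ccc3nc(COc4cccc(C(=O)O)c4)n(C)c3c2)n1` differs from compound 3 in one place, with 6-methylpyridin-2-yl in place of 6-chloropyridin-2-yl methyl in place of chloro on an aromatic carbon and the rest of the structure unchanged.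

Within the data shown here, the only measured step that bears on this change is a number 0.20 log units higher from compound 1 to compound 2 (within the scatter) and it is an indirect guide, as 2,3-dihydro-1H-inden-5-yl replaces 4-chloro-3-fluorophenyl there. Among the measured compounds shown here, no measured pair shows methyl in place of chloro. No step beyond the scatter is therefore expected in this assay and no direction is firmly supported. The estimated step is a number 0.20 log units lower from compound 3 to compound 4 (within the scatter) as a working figure. For compound 4 the expected value is 1 with an estimated range from 0.6 to 1.4 in this measurement.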

Compound 4, distribution coefficient: 0.8
Compound 4: middle estimate off by 0.20 log units, on the high side; measured number inside the range.
By their numbers in this assay, from the lowest: compound 4; then compounds 3, 1 and 2 (each within the scatter of the next, the first and the last beyond it).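

Among these compounds, this is the first measured pair in this assay that isolates methyl in place of chloro, here on an aromatic carbon next to the ring nitrogen, and it reads a number 0.40 log units lower from compound 3 to compound 4 (beyond the scatter). Among the compounds shown here, it is also the first step between compounds differing in one place to pass beyond the scatter, whereas a number 0.20 log units higher from compound 1 to compound 2 (within the scatter), although that step exchanges a whole group on the oxygen. No supporting measurement is available to explain the direction or size of the new step.

Going by these compounds, whether other groups at this position, such as a methoxy group, an amine or a nitrile, would follow chloro or methyl remains open. Also open, on these data alone, is whether methyl in place of chloro on the 4-chloro-3-fluorophenyl group of compound 1 would give a step of similar size.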